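The compounds below may be only part of what the source reports. "The series", "measured", "known", "first", "only" and "open" are said of these compounds alone.

Measured so far:
- compound 1 `O=C1/C(=C\c2ccncc2)C(c2ccccc2)Oc2ccccc21` gives 4600 nM
- compound 2 `O=c1c(Cc2ccc([N+](=O)[O-])cc2)coc2ccccc12` gives 6100 nM

Both values come from a functional assay on WM-115 cells (Homo sapiens) for cytotoxicity, read by MTT assay, with a stated time of 46 h (a lower number here means a stronger inhibitor, a higher number a weaker inhibitor), and lie within the scatter of each other, so compound 2 stands level with compound 1 on these numbers. Compound 3 `O=c1c(Cc2ccc(F)cc2)coc2ccccc12` has fluoro in place of nitro on an aromatic carbon, para to a large group: fluoro in place of nitro on an aromatic carbon. Among the compounds with values here, no measured pair shows such an exchange, so no step beyond the scatter is expected in this assay. The estimated step is a 1.2-fold higher number from compound 2 to compound 3 (0.09 log units; within the scatter) and its direction is uncertain. For compound 3 the expected value is 7500 nM, with an estimated range from 2800 nM to 20000 nM.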

Compound 3, half-maximal inhibitory concentration: 53200 nM
Estimate against measurement, compound 3: 7.1-fold (0.85 log units) below; the whole stated range lies below it.
By their numbers in this assay, from the lowest: compounds 1 and 2 (each within the scatter of the next); then compound 3.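

In this assay, the aromatic carbon para to a large group proves sensitive to what it carries: fluoro in place of nitro gives an 8.7-fold higher number from compound 2 to compound 3 (0.94 log units; beyond the scatter) and is the first step beyond the scatter among these compounds. Of this pair, the compound with nitro is the stronger inhibitor. Nothing at hand accounts for this step. With only these two groups compared at this position, the compounds leave open where an amine, a methoxy group or a carboxylic acid would fall. They also leave open whether nitro strengthens inhibition or fluoro weakens it, as the same core without either group is not among them.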